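Replacing a nitrogen-rich side chain by a benzyloxycarbonyl side chain

This account rests on a few compounds, and the source may have more. Where it says the series, first, only, none or still open, it means among the compounds named here.

Measured compounds:
compound 1 `C[C@H](NC(=O)CN(c1nc(Cl)nc2[nH]cnc12)C1CC1)C(=O)OCc1ccccc1` 23%
compound 2 `CC(C)[C@H](NC(=O)CN(c1nc(Cl)nc2[nH]cnc12)C1CC1)C(=O)OCc1ccccc1` 17.9%
compound 3 `N=C(N)NCCC[C@H](NC(=O)CN(c1nc(Cl)nc2[nH]cnc12)C1CC1)C(=O)OCc1ccccc1` 6.12%

In a functional assay on the whole organism (Tail, strain ICR) with Mus musculus as the target, in the tail flick test, with a stated time of 150 min, at a dose of 25 umol/kg by the oral route (a lower number here means a weaker effect, a higher number a stronger effect of the compound at the dose given), compound 3 stands lowest of the three, with compound 2 above it by a number 11.8 percentage points lower from compound 2 to compound 3 (beyond the scatter) and compound 1 above it by a number 16.9 percentage points lower from compound 1 to compound 3 (beyond the scatter). Compound 4 `O=C(CN(c1nc(Cl)nc2[nH]cnc12)C1CC1)N[C@@H](CC(=O)OCc1ccccc1)C(=O)OCc1ccccc1` has not been measured. Its change from compound 3 is a group of 10 heavy atoms (8 carbon, 2 oxygen; one six-membered aromatic ring of carbon only) in place of a group of 6 heavy atoms (3 carbon, 3 nitrogen; no ring), on a saturated chain carbon, two bonds along the chain from an amide-type nitrogen and a carbonyl carbon. The step that bears on it is the one at the same place, where a hydrogen of compound 1 became the six-atom group of compound 3 and gave a number 16.9 percentage points lower from compound 1 to compound 3 (beyond the scatter); the step of a number 5.1 percentage points lower from compound 1 to compound 2 (within the scatter) at the neighbouring carbon stayed within the scatter. Among the compounds with values here, no measured compound carries a benzyloxycarbonyl at this place. Compound 4 is therefore expected to rise modestly toward the level of compound 1, by an estimated a number 11.9 percentage points higher from compound 3 to compound 4 (beyond the scatter), giving an expected 18% with a range from 7% to 30%.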

Compound 4, a percentage reported as activity, at one dose (the size of the read-out at that dose, not a potency): 6.68%
For compound 4 the middle estimate is 11.3 percentage points above the measured one, and the stated range ends above it.
By their numbers in this assay, from the lowest: compounds 3 and 4 (each within the scatter of the next); then compounds 2 and 1 (each within the scatter of the next).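

Exchanging the group of three nitrogens for benzyloxycarbonyl at this place gives a number 0.6 percentage points higher from compound 3 to compound 4 (within the scatter) in this assay and so does not restore the level of the hydrogen compound. Set against hydrogen, benzyloxycarbonyl gives a number 16.3 percentage points lower from compound 1 to compound 4 (beyond the scatter) and thus shows that a loss beyond the scatter at this place also occurs with a group carrying no nitrogen. Read as (benzyloxycarbonyl)methyl in place of isopropyl, the change gives a number 11.2 percentage points lower from compound 2 to compound 4 (beyond the scatter) as well.

From the compounds shown here alone, whether a carboxylic acid or a primary amine at this place would stay at the level of compound 1 remains open, and no evidence bears on this result.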